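Methylsulfanyl on the Core of a Thromboxane Synthase Inhibitor

The source may report more compounds than this note shows. Statements on the series, on what has been measured and on what is new or still open speak of the compounds shown alone.

Working notes on the series. Compound 1 `Cc1c(Cn2ccnc2)sc2cc(C(=O)O)ccc12` and compound 2 `O=C(O)c1ccc2sc(Cn3ccnc3)cc2c1` share a core carrying a carboxylic acid and a (1H-imidazol-1-yl)methyl group. In an assay for inhibition of Thromboxane-A synthase (Homo sapiens) (a higher number here means a weaker inhibitor, a lower number a stronger inhibitor), compound 1 gives 18 nM, and compound 2 gives 15 nM; compound 2 shows the lowest of the two numbers, but its gap to compound 1 lies within the scatter. Compound 3 `CSc1c(Cn2ccnc2)sc2ccc(C(=O)O)cc12` carries methylsulfanyl in place of hydrogen on an aromatic carbon. Going by the values given here, no step between measured compounds is known, and compound 1, with a methyl on the core, sits within the scatter of compound 2, so no shift beyond the scatter is expected for compound 3 in this assay. Compound 3 is estimated at 20 nM, range 8 nM to 50 nM. The expected step of a 1.3-fold higher number from compound 2 to compound 3 (0.12 log units; within the scatter) is within the scatter.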

Compound 3, half-maximal inhibitory concentration: 43 nM
Compound 3: middle estimate off by 2.2-fold (0.33 log units), on the low side; low and high end bracket the measured number.
By their numbers in this assay, from the lowest: compounds 2 and 1 (each within the scatter of the next); then compound 3.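

Methylsulfanyl in place of hydrogen, on the aromatic carbon next to the ring atom that bears a (1H-imidazol-1-yl)methyl group, gives the only step beyond the scatter in the series, a 2.9-fold higher number from compound 2 to compound 3 (0.46 log units; beyond the scatter), in this assay. This position therefore responds to this change, though only modestly, and compound 3 still gives 43 nM. Nothing available on these compounds accounts for the step.

Going by these compounds, whether the step is particular to methylsulfanyl stays open. A methoxy group, a chlorine or an amine at this position could show whether other groups keep the number near that of compound 2.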